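The compounds below may be only part of what the source reports. "The series", "measured", "known", "first", "only" and "open" are said of these compounds alone.

In an ADME assay on MRC5 cells (Homo sapiens), read by MTT assay, with a stated time of 72 h (on this read-out higher numbers stand for weaker inhibition and lower numbers for stronger inhibition), compound 1 `COc1ncnc2c1c(-c1ccoc1)cn2[C@@H]1O[C@H](CO)[C@@H](O)[C@H]1O` gives 29400 nM. Compound 2 `CNc1ncnc2c1c(-c1ccoc1)cn2[C@@H]1O[C@H](CO)[C@@H](O)[C@H]1O` reaches only a limit of this assay, > 100000 nM. Compound 3 `CNc1ncnc2c1c(-c1ccco1)cn2[C@@H]1O[C@H](CO)[C@@H](O)[C@H]1O` gives 90800 nM in this assay. Compound 3 differs from compound 2 in its core, (furan-2-yl in place of furan-3-yl on an aromatic carbon), a change that made an at least 1.1-fold lower number from compound 2 to compound 3 (0.04 log units; that floor lies within the scatter). The other change seen, (methoxy in place of methylamino on an aromatic carbon), made an at least 3.4-fold lower number from compound 2 to compound 1 (0.53 log units; beyond the scatter); that step is known only as a bound because of the limit of > 100000 nM in this assay, at which 1 of the 3 values shown sits. Compound 4 `COc1ncnc2c1c(-c1ccco1)cn2[C@@H]1O[C@H](CO)[C@@H](O)[C@H]1O` has not been measured in this assay; it carries the same change on the core of compound 3, (methoxy in place of methylamino on an aromatic carbon). For compound 4 in this assay a step of a 3.2-fold lower number from compound 3 to compound 4 (0.51 log units; beyond the scatter) is expected. That expectation rests on the step already seen, an at least 3.4-fold lower number from compound 2 to compound 1 (0.53 log units; beyond the scatter), made by the same change on the core of compound 2. Compound 4 is therefore estimated at 28000 nM, most likely between 10000 nM and 80000 nM.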

Compound 4, half-maximal inhibitory concentration: 1700 nM
The estimate for compound 4 lay 16-fold (1.22 log units) above the measured number; measured number below the stated range.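

In this assay, methoxy in place of methylamino gives a 53-fold lower number from compound 3 to compound 4 (1.73 log units; beyond the scatter), and furan-2-yl in place of furan-3-yl gives a 17-fold lower number from compound 1 to compound 4 (1.24 log units; beyond the scatter). The methoxy change lowers the number on both cores, which shows that its direction carried over, but it does not show that its size did: the same change on two cores in this assay, an at least 3.4-fold lower number (0.53 log units; beyond the scatter) from compound 2 to compound 1 and a 53-fold lower number (1.73 log units; beyond the scatter) from compound 3 to compound 4; the limit leaves it open whether they differ The furan change can be read no more firmly, since compound 2 sits at a limit of the assay: the same change on two cores in this assay, an at least 1.1-fold lower number (0.04 log units; that floor lies within the scatter) from compound 2 to compound 3 and a 17-fold lower number (1.24 log units; beyond the scatter) from compound 1 to compound 4; the limit leaves it open whether they differ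

The compounds shown leave open how an unsubstituted amine or a longer alkoxy chain would read in place of methoxy. They also leave open whether the large methoxy step would hold with a group other than a furan on the core.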